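Hydrazone aryl variation in a glioblastoma cytotoxicity series

The source may report more compounds than this note shows. Statements on the series, on what has been measured and on what is new or still open speak of the compounds shown alone.

Measured compounds:
compound 1 `CN(C)CCn1cnnc1-c1cc(Oc2ccc(NC(=O)N/N=C/c3ccc(F)cc3)cc2F)ccn1`: 2310 nM
compound 2 `CN(C)CCn1cnnc1-c1cc(Oc2ccc(NC(=O)N/N=C/c3ccc(O)cc3)cc2F)ccn1`: 7750 nM

Compound 1 and compound 2 share a core and differ only in the hydrazone aryl group. In a functional assay on U-87MG ATCC cells (Homo sapiens) for cytotoxicity, read by MTT assay, with a stated time of 72 h (on this read-out higher numbers stand for weaker inhibition and lower numbers for stronger inhibition), compound 1 gives 2310 nM, while compound 2 gives 7750 nM. The change is a 3.4-fold higher number from compound 1 to compound 2 (0.53 log units; beyond the scatter), so compound 2 stands at the higher of the two numbers shown, with compound 1 as its only neighbour.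

Compound 3 `COc1ccc(/C=N/NC(=O)Nc2ccc(Oc3ccnc(-c4nncn4CCN(C)C)c3)c(F)c2)cc1O` carries the difference (3-hydroxy-4-methoxyphenyl in place of 4-hydroxyphenyl on a carbon with a double bond to nitrogen). The hydroxy group of compound 2 is kept, and a methoxy group is added to the same ring.

For the measured compounds named here, only one measured step bears on this position, the step of a 3.4-fold higher number from compound 1 to compound 2 (0.53 log units; beyond the scatter), and it concerns a different exchange, fluoro against hydroxy. Going by the values given here, no measured pair shows what adding a methoxy group beside an existing hydroxy does. The expected step is therefore small and uncertain: the estimate for a 1.2-fold lower number from compound 2 to compound 3 (0.08 log units; within the scatter) is a number close to that of compound 2, with no direction beyond the scatter expected.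

The estimated value for compound 3 in this assay is 6500 nM, with a range from 2500 nM to 16000 nM.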

Compound 3, half-maximal inhibitory concentration: > 100000 nM
Compound 3: only a limit was reported; the forecaster's own chance of this, stated with the estimate: 10%; at least 15-fold (1.18 log units) between middle value and limit.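

Compound 3 shows that this position on the hydrazone tolerates much less than the first pair suggested. Putting 3-hydroxy-4-methoxyphenyl in place of 4-hydroxyphenyl on a carbon with a double bond to nitrogen gives an at least 12-fold higher number from compound 2 to compound 3 (1.11 log units; beyond the scatter), a large step where the exchange of fluoro for hydroxy was only modest, and the same group in place of 4-fluorophenyl gives an at least 43-fold higher number from compound 1 to compound 3 (1.63 log units; beyond the scatter). In this assay compound 3 reads only as a limit and not as a number, so both steps give a floor for the change and not its full size: the limit of > 100000 nM in this assay, at which 1 of the 3 values shown sits.

The compounds shown leave open whether the added methoxy group alone accounts for this large step or whether it depends on the methoxy and hydroxy groups sitting together on the same ring, as a ring carrying methoxy without hydroxy is not among them. They also leave open how an amine or a carboxylic acid on this aryl ring would read, and whether any group here can bring the number lower than that of compound 1.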